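Shortening a Fluorinated Ester on a Shared Core

The compounds below may be only part of what the source reports. "The series", "measured", "known", "first", "only" and "open" are said of these compounds alone.

Compound 1 `CC1=C(C(=O)OC(C(F)(F)F)C(F)(F)F)C(c2ccsc2)NC(=O)N1`: 1%
Compound 2 `CC1=C(C(=O)OC(C(F)(F)F)C(F)(F)F)C(c2ccoc2)NC(=O)N1`: 2%

In an assay on HEK293 cells for displacement of a labelled ligand from adenosine receptor A2b (Homo sapiens), read by radioligand binding, with a stated time of 30 min, tested at 1 uM (a lower number here means less inhibition, a higher number more inhibition at the concentration tested (going by the name of the read-out)), compound 1 gives 1%, the lowest of the two numbers, while compound 2 gives 2%, and the step of a number 1 percentage points higher from compound 1 to compound 2 (within the scatter) lies within the scatter. Compound 3 `CC1=C(C(=O)OCC(F)(F)F)C(c2ccsc2)NC(=O)N1` differs from compound 1 by hydrogen in place of trifluoromethyl on a saturated chain carbon bound to an oxygen next to a carbonyl group and a saturated chain carbon. Going by the values given here, no measured step touches this part of the molecule, so nothing here points to a change beyond the scatter. Compound 3 is therefore expected to give 3%, within -8% to 15%, a step of a number 2 percentage points higher from compound 1 to compound 3 (within the scatter).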

Compound 3, a percentage reported as inhibition, at one concentration (the size of the read-out at that concentration, not a potency): 24%
Beside the measured number, compound 3's estimate is 21 percentage points below it; measured number above the stated range.
By their numbers in this assay, from the lowest: compounds 1 and 2 (each within the scatter of the next); then compound 3.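

In this assay, hydrogen in place of trifluoromethyl at this saturated chain carbon gives a number 23 percentage points higher from compound 1 to compound 3 (beyond the scatter), so this position moves the read-out, whereas the ring swap gave only a number 1 percentage points higher from compound 1 to compound 2 (within the scatter). Even so, compound 3 gives 24%, a size at a single concentration and not a potency. Nothing measured here bears on why removing one trifluoromethyl has this effect.

Going by these compounds, what a longer chain or an amine at this carbon would give remains open. So does whether furan-3-yl and thiophen-3-yl stay level once this trifluoromethyl has gone.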